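The source may report more compounds than this note shows. Statements on the series, on what has been measured and on what is new or still open speak of the compounds shown alone.

Measured compounds:
compound 1 `O=C(Nc1cccc(-n2cc(-c3ccncc3)c(-c3ccc(Cl)c(O)c3)n2)c1)Nc1cccc(C(F)(F)F)c1` — 1570 nM
compound 2 `COc1cc(-c2nn(-c3cccc(NC(=O)Nc4cccc(C(F)(F)F)c4)c3)cc2-c2ccncc2)ccc1Cl` — 739 nM

Among the measured compounds shown here, in a functional assay on OVCAR-8 cells (Homo sapiens) for inhibition, read by sulforhodamine B assay, with a stated time of 48 h (on this read-out higher numbers stand for weaker inhibition of growth and lower numbers for stronger inhibition of growth), compound 2 holds the lowest of the two numbers; its nearest neighbour is compound 1, and the step of a 2.1-fold lower number from compound 1 to compound 2 (0.33 log units; beyond the scatter) is the only one between the measured compounds, a modest one and beyond the scatter.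

Compound 3 `COc1cc(-c2nn(-c3cccc(NC(=O)c4ccccc4)c3)cc2-c2ccncc2)ccc1Cl` is unmeasured. It differs from compound 2 in one place: phenyl in place of (3-(trifluoromethyl)phenyl)amino on a carbonyl carbon. The urea of compound 2 thus becomes a benzamide, the carbonyl now bearing a phenyl directly in place of the (3-(trifluoromethyl)phenyl)amino group.

For the measured compounds named here, no measured step covers this change. Going by the values given here, the one step in hand, from compound 1 to compound 2, concerns the oxygen on the other aromatic ring and leaves the urea end untouched, so it gives no guidance on the size or direction of the move from compound 2 to compound 3. The expectation rests only on the fact that a sizeable portion of the molecule is removed, so the estimate for compound 3 is a weaker inhibition, a step of a 4.1-fold higher number from compound 2 to compound 3 (0.61 log units; beyond the scatter), with a wide range. The estimated value for compound 3 in this assay is 3000 nM, within 800 nM to 12000 nM.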

Compound 3, concentration for 50% growth inhibition: 995 nM
Compound 3: middle estimate off by 3.0-fold (0.48 log units), on the high side; measured number inside the range.
By their numbers in this assay, from the lowest: compounds 2, 3 and 1 (each within the scatter of the next, the first and the last beyond it).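

In this assay, phenyl in place of (3-(trifluoromethyl)phenyl)amino on the carbonyl carbon gives a 1.3-fold higher number from compound 2 to compound 3 (0.13 log units; within the scatter), so this read-out does not separate the urea of compound 2 from the benzamide of compound 3. The earlier pair left this end of the molecule untouched, and this pair shows that, for these two compounds, neither the trifluoromethyl group nor the hydrogen-bond donor of the leaving group is needed to keep the number within the scatter. No measurement at hand bears on why the number stays within the scatter after this change.

Among the compounds shown here, still open is whether a 2.1-fold lower number from compound 1 to compound 2 (0.33 log units; beyond the scatter) carries over to the benzamide, since that step was seen only with the urea in place. Also open, from the compounds shown here alone, is what a cyclohexyl or a morpholine would give on the same carbonyl carbon, and whether a trifluoromethyl on the phenyl of compound 3 would move the number at all, which would separate the part played by that group from the part played by the urea nitrogen.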